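Permeability notes: aryl swap at the shared core

The compounds below may be only part of what the source reports. "The series", "measured", "known", "first", "only" and "open" are said of these compounds alone.

compound 1 `Fc1ccc(-c2ccc3c(NCCCNCc4ccco4)ccnc3c2)cc1` — 237 10^-6 cm/s
compound 2 `COc1cccc(CNCCCNc2ccnc3cc(-c4ccc(F)cc4)ccc23)c1O` — 237 10^-6 cm/s
compound 3 `COc1ccc(F)cc1CNCCCNc1ccnc2cc(-c3ccc(F)cc3)ccc12` — 237 10^-6 cm/s

In an ADME assay for permeability, using PAMPA, with a stated time of 30 min, at pH 7.4 (on this read-out lower numbers stand for lower permeability and higher numbers for higher permeability), compound 2 stands level with compounds 1 and 3. The steps of no change at the digits printed from compound 1 to compound 2 (within the scatter), no change at the digits printed from compound 1 to compound 3 (within the scatter) and no change at the digits printed from compound 2 to compound 3 (within the scatter) all vary only the group on the saturated chain carbon bound to the amine nitrogen, and none moves the read-out beyond the scatter. Compound 4 `COc1ccc(Oc2ccc3c(NCCCNCc4cccc(OC)c4O)ccnc3c2)cc1` changes a different part of the molecule: 4-methoxyphenoxy in place of 4-fluorophenyl on an aromatic carbon. Going by the values given here, no measured step touches that position, and the three measured compounds show only that this series sits at one shared value. Compound 4 is expected to stay close to compound 2, with a 1.1-fold lower number from compound 2 to compound 4 (0.03 log units; within the scatter) estimated as no step beyond the scatter. The estimate for compound 4 is 220 10^-6 cm/s, range 110 10^-6 cm/s to 300 10^-6 cm/s.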

Compound 4, apparent permeability: 317 10^-6 cm/s
For compound 4 the middle estimate is 1.4-fold (0.16 log units) below the measured one; measured number above the stated range.
By their numbers in this assay, from the lowest: compounds 1, 2, 3 and 4 (each within the scatter of the next).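

In this assay, going by these compounds alone, the first measured change at this aromatic carbon, 4-methoxyphenoxy in place of 4-fluorophenyl, gives a 1.3-fold higher number from compound 2 to compound 4 (0.13 log units; within the scatter). The position therefore accepts an entering group with more heavy atoms and more hydrogen-bond acceptors than the leaving one, with no step beyond the scatter. No measurement at hand offers an explanation for this result. Still open, as far as these compounds go, is how an amine or a carboxylic acid on this aromatic carbon would read. Also open, from the compounds shown here alone, is whether 4-methoxyphenoxy gives the same reading alongside furan-2-yl or 5-fluoro-2-methoxyphenyl on the saturated chain carbon.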